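This account rests on a few compounds, and the source may have more. Where it says the series, first, only, none or still open, it means among the compounds named here.

Compound 1 `N#Cc1ccc(S(=O)(=O)N2C/C(=C\c3ccccc3F)C(=O)/C(=C/c3ccccc3F)C2)cc1` gives 14600 nM in a functional assay on SMMC-7721 cells (Homo sapiens) for cytotoxicity, read by MTT assay, with a stated time of 24 h; a higher number here means a weaker inhibitor, a lower number a stronger inhibitor. Compound 2 `CC(=O)Nc1ccc(S(=O)(=O)N2C/C(=C\c3ccccc3F)C(=O)/C(=C/c3ccccc3F)C2)cc1` gives 7500 nM. Compound 3 `N#Cc1ccc(S(=O)(=O)N2C/C(=C\c3ccc(F)cc3)C(=O)/C(=C/c3ccc(F)cc3)C2)cc1` gives 15000 nM.

Compound 1 and compound 2 share a core and differ in one place, (acetamido in place of cyano on an aromatic carbon). That change made a step of a 1.9-fold lower number from compound 1 to compound 2 (0.29 log units; within the scatter). Compound 3 carries a different core; how that core differs from the core of compound 1 is not broken down here, and the two values lie within the scatter of each other. Compound 4 `CC(=O)Nc1ccc(S(=O)(=O)N2C/C(=C\c3ccc(F)cc3)C(=O)/C(=C/c3ccc(F)cc3)C2)cc1` stands to compound 3 as compound 2 stands to compound 1: the difference is acetamido in place of cyano on an aromatic carbon, the same change at the same kind of place. Because the earlier step was a 1.9-fold lower number from compound 1 to compound 2 (0.29 log units; within the scatter), a step of about a 1.9-fold lower number from compound 3 to compound 4 (0.27 log units; within the scatter) is expected from the same change on the core of compound 3. Compound 4 is therefore estimated at 8000 nM in this assay, expected between 4000 nM and 16000 nM.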

Compound 4, half-maximal inhibitory concentration: 9800 nM
The estimate for compound 4 lay 1.2-fold (0.09 log units) below the measured number, within the range that was stated.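

In this assay, acetamido in place of cyano on an aromatic carbon gives a 1.5-fold lower number from compound 3 to compound 4 (0.18 log units; within the scatter). Set beside the earlier step, the change reads alike on the two cores: the same change on two cores in this assay, a 1.9-fold lower number (0.29 log units; within the scatter) from compound 1 to compound 2 and a 1.5-fold lower number (0.18 log units; within the scatter) from compound 3 to compound 4, 1.3-fold (0.10 log units) apart, within the scatter of two such steps. Both steps lie within the scatter, so this shows only that no difference between the cores can be detected for this change; it does not show that the change itself moves the number, nor that it would carry to any further core.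

The compounds shown leave open how an amine, a carboxylic acid or a longer acyl chain would read in place of the cyano group. Also open, as far as these compounds go, is whether the same change reads alike on a core with chlorine or methoxy in place of fluorine.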